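The source may hold more compounds than are shown below. What is called first, only, known or untested is meant among the compounds shown, and "the series" means these compounds.

- Compound 1 `COc1ccc(-c2cc3c(OC)cc(OC)cc3n(CCCC#N)c2=O)cc1`: 10000 nM
- Compound 2 `COc1ccc(-c2cc3c(OC)cc(OC)cc3n(CC(=O)O)c2=O)cc1`: 10000 nM
- Compound 3 `COC(=O)CCn1c(=O)c(-c2ccc(OC)cc2)cc2c(OC)cc(OC)cc21`: 10000 nM

All three values come from a functional assay on J82 cells (Homo sapiens) for cytotoxicity, read by colorimetric assay and MTT assay; a lower number here means a stronger inhibitor, a higher number a weaker inhibitor. Compound 3 stands level with compound 1 and compound 2, so none of the three can be ranked above the others.

The next compound, compound 4 `CCN(CC)C(=O)CCn1c(=O)c(-c2ccc(OC)cc2)cc2c(OC)cc(OC)cc21`, keeps the core of compound 3 and changes only the end of its chain. The ester of compound 3 becomes an amide, with diethylamino in place of methoxy on a carbonyl carbon. Put another way, methoxycarbonyl becomes diethylcarbamoyl.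

Three measured steps changed the chain on the aromatic nitrogen: no change at the digits printed from compound 1 to compound 3 (within the scatter), no change at the digits printed from compound 2 to compound 3 (within the scatter) and no change at the digits printed from compound 1 to compound 2 (within the scatter). Each of these steps was flat, even though nitrile, carboxy and methoxycarbonyl chain ends were exchanged. Going by the values given here, none of the measured compounds carries a diethylcarbamoyl group, however, so this expectation rests on indirect evidence.

On these steps alone, no shift beyond the scatter is expected in this assay, and the expected step is no change at the digits printed from compound 3 to compound 4 (within the scatter). For compound 4 the estimated value is 10000 nM, with an expected range of 3000 nM to 20000 nM.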

Compound 4, half-maximal inhibitory concentration: 10000 nM
For compound 4 middle estimate and measured number coincide at the digits printed; the range from low to high includes it.
By their numbers in this assay, from the lowest: compounds 1, 2, 3 and 4 (each within the scatter of the next).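

In this assay, replacing methoxy (2 heavy atoms) with diethylamino (5 heavy atoms) on a carbonyl carbon turns the ester into an amide and gives no change at the digits printed from compound 3 to compound 4 (within the scatter), so this position now has its first direct test of a larger, amide-type chain end. The same holds against the other two chain ends, with no change at the digits printed from compound 2 to compound 4 (within the scatter) for the swap from carboxy to (diethylcarbamoyl)methyl and no change at the digits printed from compound 1 to compound 4 (within the scatter) for the swap from cyanomethyl to diethylcarbamoyl, which means that nitrile, carboxy, methoxycarbonyl and diethylcarbamoyl chain ends on this shared core cannot be told apart in this cell test. No measurement available here explains why the result stays flat.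

From the compounds shown here alone, it remains open whether any chain end on the aromatic nitrogen can shift the value, for example a free amine, a hydroxyl or a ring-bearing amide such as a morpholine amide, or a longer chain. Going by these compounds, it is equally open whether a change elsewhere on the core, such as hydroxyl in place of one of the methoxy groups, would separate these compounds.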